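The source may report more compounds than this note shows. Statements on the series, on what has been measured and on what is new or still open speak of the compounds shown alone.

Measured in a functional assay on MCF7 cells (Homo sapiens) for antiproliferative activity, read by MTT assay, with a stated time of 72 h; a lower number here means a stronger inhibitor, a higher number a weaker inhibitor:

Compound 1 `C/C=C/C(=O)Nc1cccc(Oc2nc(Nc3cccc(C#N)c3)nc3c2CSCC3)c1`: 21400 nM
Compound 2 `C=CC(=O)Nc1cccc(Oc2nc(Nc3ccc(OC)nc3)nc3c2CSCC3)c1`: 17200 nM

Compound 2 stands within the usual scatter of compound 1, so these two numbers cannot be told apart and neither compound can be ranked over the other. Compound 3 `C/C=C/C(=O)Nc1cccc(Oc2nc(Nc3ccc(OC)nc3)nc3c2CSCC3)c1` is compound 2 with prop-1-en-1-yl in place of vinyl on a carbonyl carbon. Going by the values given here, no two measured compounds differ in one place only, so the size of this change has not been seen directly in this assay. Among the compounds with values here, the only guide is compound 1, which carries the same prop-1-en-1-yl group on its carbonyl carbon and gives 21400 nM. That guide is limited, since compound 1 and compound 3 also differ elsewhere in their structures. Nothing measured therefore points to a shift in either direction, and no change beyond the scatter is expected. The estimated step of a 1.2-fold higher number from compound 2 to compound 3 (0.07 log units; within the scatter) accordingly stays small. The value of compound 3 is expected to be about 20000 nM, within an estimated range of 9000 nM to 45000 nM.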

Compound 3, half-maximal inhibitory concentration: 21100 nM
Compound 3: the middle estimate sits 1.1-fold (0.02 log units) below what was measured; low and high end bracket the measured number.
By their numbers in this assay, from the lowest: compounds 2, 3 and 1 (each within the scatter of the next).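

Going by these compounds alone, compound 3 gives the first direct reading of this position in this assay and the step of a 1.2-fold higher number from compound 2 to compound 3 (0.09 log units; within the scatter) shows that, with the rest of the structure held the same, prop-1-en-1-yl in place of vinyl on a carbonyl carbon leaves two numbers that cannot be told apart. Compound 3 also provides a single-place comparison at a second site, where the step of a 1.0-fold lower number from compound 1 to compound 3 (0.01 log units; within the scatter) shows that 6-methoxypyridin-3-yl in place of 3-cyanophenyl on a nitrogen on an aromatic ring likewise cannot be told apart from the scatter. Across these two steps, neither exchange moves the number beyond the scatter, so neither group can be ranked over its partner at its site.

On these data alone, it remains open whether a different group on the carbonyl carbon, such as a saturated ethyl chain, a longer chain or a vinyl group carrying an amine, would give a number beyond the scatter. The same question stands for the aromatic group on the nitrogen, where an unsubstituted phenyl or a phenyl carrying a carboxylic acid would test that site further. No measurement at hand explains these readings.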